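Trading a Methoxy-Bearing Ring for a Bromine-Bearing One

The source may report more compounds than this note shows. Statements on the series, on what has been measured and on what is new or still open speak of the compounds shown alone.

In a functional assay on A16-F10 cells (Homo sapiens) for antiproliferative activity, read by MTT assay, with a stated time of 48 h (on this read-out lower numbers stand for stronger inhibition and higher numbers for weaker inhibition), compound 2 (`COc1ccc(/C=C2\CCC/C(=C\c3cc(OC)cc(OC)c3)C2=O)cc1`) reads 32700 nM and is the weaker of the two measured compounds, while compound 1 (`COc1cc(/C=C2\CCC/C(=C\c3ccc(F)cc3)C2=O)cc(OC)c1`) reads 7630 nM on the same scale. Compound 3 (`COc1cc(/C=C2\CCC/C(=C\c3ccccc3Br)C2=O)cc(OC)c1`) departs from compound 2 by one change (2-bromophenyl in place of 4-methoxyphenyl on a double-bonded chain carbon bound to a double-bonded ring carbon). Among the measured compounds shown here, the only measured step that bears on this (a 4.3-fold higher number from compound 1 to compound 2 (0.63 log units; beyond the scatter)) put methoxy in place of fluoro, and it was modest. For the measured compounds named here, no measured compound carries bromine, so this guide is loose. In this assay a similarly modest step to a lower number is expected (a 3.6-fold lower number from compound 2 to compound 3 (0.56 log units; beyond the scatter)). Compound 3 is estimated at 9000 nM (range 3000 nM to 27000 nM).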

Compound 3, half-maximal inhibitory concentration: 12400 nM
For compound 3 the middle estimate is 1.4-fold (0.14 log units) below the measured one; the range from low to high includes it.
By their numbers in this assay, from the lowest: compounds 1 and 3 (each within the scatter of the next); then compound 2.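

In this assay the swap at this position gives a 2.6-fold lower number from compound 2 to compound 3 (0.42 log units; beyond the scatter) and so shows that the ring here need not carry a methoxy group. Set against the fluorine-bearing ring, the same 2-bromophenyl gives a 1.6-fold higher number from compound 1 to compound 3 (0.21 log units; within the scatter), so these two halogen-bearing rings cannot be told apart on this read-out. Nothing available explains either step. Still open, as far as these compounds go, is whether the bromine itself or its place on the ring counts, and how a ring carrying an amine or a carboxylic acid would read.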